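Shortening the Amino Chain on a Shared Core

The compounds below may be only part of what the source reports. "The series", "measured", "known", "first", "only" and "open" are said of these compounds alone.

Compound 1 `C=CCNc1nnc(SCC(=O)N(Cc2cccc([N+](=O)[O-])c2)c2ccc(F)cc2)s1` gives 92% in an assay on isolated protein for inhibition of Amine oxidase [flavin-containing] A (Homo sapiens), read by fluorescence and Amplex Red, with a stated time of 30 min, tested at 1 mM; on this read-out lower numbers stand for a weaker effect and higher numbers for a stronger effect at the one concentration tested.
Compound 2 `CCCNc1nnc(SCC(=O)N(Cc2cccc([N+](=O)[O-])c2)c2ccc(F)cc2)s1` gives 95% in this assay.

Among the compounds with values here, compound 2 holds the higher of the two numbers, but its only neighbour is close: the step of a number 3 percentage points higher from compound 1 to compound 2 (within the scatter) lies within the scatter, so the two compounds cannot be told apart on these data.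

Compound 3 `CCNc1nnc(SCC(=O)N(Cc2cccc([N+](=O)[O-])c2)c2ccc(F)cc2)s1` is the next compound. It differs from compound 2 by hydrogen in place of methyl on a saturated chain carbon, two bonds along the chain from a nitrogen on an aromatic ring. Within the data shown here, the one measured step, a number 3 percentage points higher from compound 1 to compound 2 (within the scatter), concerns the same chain on the same nitrogen, ethyl in place of vinyl on a saturated chain carbon bound to a nitrogen on an aromatic ring, and it did not move the read-out beyond the scatter. Both measured compounds sit near the top of the scale, which leaves little room upward. The expectation for compound 3 is therefore a step of about a number 3 percentage points lower from compound 2 to compound 3 (within the scatter), no change beyond the scatter. The estimated value for compound 3 in this assay is 92%, within a range from 82% to 99%.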

Compound 3, a percentage reported as inhibition, at one concentration (the size of the read-out at that concentration, not a potency): 93.6%
The estimate for compound 3 lay 1.6 percentage points below the measured number; the range from low to high includes it.
By their numbers in this assay, from the lowest: compounds 1, 3 and 2 (each within the scatter of the next).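

Shortening the propylamino chain to ethylamino on the shared core gives a number 1.4 percentage points lower from compound 2 to compound 3 (within the scatter) in this assay, and replacing the vinyl end of the chain in compound 1 gives a number 1.6 percentage points higher from compound 1 to compound 3 (within the scatter) for the same ethylamino compound. The earlier pair compared only two chains of the same length, whereas this result shows that removing the outer methyl, and so changing the chain length, also leaves the read-out within the scatter; compound 1, compound 2 and compound 3 therefore cannot be put in any order, and at this one concentration, near the top of the scale, this position tolerates all three chains. Nothing available here explains why the number holds across these chains.

The compounds shown leave open how far this tolerance extends, whether to a methylamino group or a bare amino group at the short end, or to a butyl chain or a branched isopropyl group at the other. Any real differences among the three chains could also stay hidden until they are compared through full concentration-response curves rather than a single high concentration.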